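The source may report more compounds than this note shows. Statements on the series, on what has been measured and on what is new or still open speak of the compounds shown alone.

Compound 1, `Cc1cc(C)cc(Nc2nccc(-c3ccccn3)n2)c1`, is the anchor of this small set. In a functional assay for inhibition, with Homo sapiens as the target (a higher number here means a weaker inhibitor, a lower number a stronger inhibitor), compound 1 gives 100 nM. Compound 2, `Cc1cc(C)cc(Nc2nccc(-c3cccnc3)n2)c1`, carries the same core but with pyridin-3-yl in place of pyridin-2-yl on an aromatic carbon, and in this assay compound 2 gives 800 nM; the step of an 8.0-fold higher number from compound 1 to compound 2 (0.90 log units; beyond the scatter) therefore lies beyond the scatter of repeated runs. Compound 3, `CNc1ccc(Nc2nccc(-c3ccccn3)n2)cc1`, differs from compound 1 in its core, and the difference between the two cores is not broken down here. In this assay compound 3 gives 1400 nM, which sits within the scatter of compound 2 and beyond it from compound 1.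

Compound 4, `CNc1ccc(Nc2nccc(-c3cccnc3)n2)cc1`, has not yet been measured. It stands to compound 3 as compound 2 stands to compound 1, through (pyridin-3-yl in place of pyridin-2-yl on an aromatic carbon), the same change at the same place. Since the earlier step is an 8.0-fold higher number from compound 1 to compound 2 (0.90 log units; beyond the scatter), a step of comparable size is expected here, estimated as a 6.4-fold higher number from compound 3 to compound 4 (0.81 log units; beyond the scatter). Resting on compound 3 at 1400 nM, compound 4 is expected to give 9000 nM in this assay, most likely between 3000 nM and 30000 nM.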

Compound 4, half-maximal inhibitory concentration: 2100 nM
Beside the measured number, compound 4's estimate is 4.3-fold (0.63 log units) above it; measured number below the stated range.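

In this assay, moving from pyridin-2-yl to pyridin-3-yl on the core of compound 3 comes to a 1.5-fold higher number from compound 3 to compound 4 (0.18 log units; within the scatter), a step that stays within the scatter. The same change therefore does not carry over at the same size between the two cores: the same change on two cores in this assay, an 8.0-fold higher number (0.90 log units; beyond the scatter) from compound 1 to compound 2 and a 1.5-fold higher number (0.18 log units; within the scatter) from compound 3 to compound 4, 5.3-fold (0.73 log units) apart, beyond the scatter of two such steps. This shows that, across these two pairs, the size of the step depends on the core, but two pairs give no rule for any other core and do not tell which part of the difference between the cores matters.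

The compounds shown leave open how pyridin-4-yl or phenyl would behave at this place on either core. They also leave open whether a third core, for instance one carrying a carboxylic acid or a longer amine chain, would show the large step, the small one or something else.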